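This account rests on a few compounds, and the source may have more. Where it says the series, first, only, none or still open, it means among the compounds named here.

Within the data shown here, compound 2 `CCOc1cncc(OC[C@@H]2CCN2)c1` stands at the lowest of the two numbers measured so far: in an assay on brain for binding affinity to Neuronal acetylcholine receptor; alpha4/beta2 (Rattus norvegicus), read by radioligand binding (a lower number here means a stronger inhibitor, a higher number a weaker inhibitor), compound 2 gives 0.039 nM. Among the measured compounds shown here, the only other measured compound, compound 1 `Nc1cncc(OC[C@@H]2CCN2)c1`, gives 0.082 nM in this assay, and the single known step is a 2.1-fold lower number from compound 1 to compound 2 (0.32 log units; beyond the scatter). The next compound, compound 3 `CC(=O)NCc1cncc(OC[C@@H]2CCN2)c1`, differs from compound 2 in one place: acetamidomethyl in place of ethoxy on an aromatic carbon. For the measured compounds named here, no measured step exchanges ethoxy for acetamidomethyl; the one step that does touch this aromatic carbon, the exchange of amino for ethoxy, moved the number only modestly. With so little to go on, the expectation is a step toward a higher number of about a 3.8-fold higher number from compound 2 to compound 3 (0.59 log units; beyond the scatter), not a large one. The estimate for compound 3 in this assay is therefore 0.15 nM, with a range from 0.03 nM to 0.8 nM.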

Compound 3, inhibition constant: 0.54 nM
The estimate for compound 3 lay 3.6-fold (0.56 log units) below the measured number; measured number inside the range.
By their numbers in this assay, from the lowest: compound 2; then compound 1; then compound 3.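

At this aromatic carbon, the group matters more than the exchange of amino for ethoxy alone could show: in this assay, acetamidomethyl brings a 14-fold higher number from compound 2 to compound 3 (1.14 log units; beyond the scatter) and also a 6.6-fold higher number from compound 1 to compound 3 (0.82 log units; beyond the scatter) in a separate comparison. Compound 3 therefore has the highest number of the three, and both steps lie beyond the scatter, so this position does not accept every substituent equally. Nothing available explains why this change costs so much.

The compounds shown cannot separate the contribution of the amide from that of the carbon linking it to the ring, a question that aminomethyl or a simple methyl group could help address. From the compounds shown here alone, whether a longer chain such as propoxy would continue the trend from amino to ethoxy also remains open.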